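This account rests on a few compounds, and the source may have more. Where it says the series, first, only, none or still open, it means among the compounds named here.

In a functional assay on SW-620 cells (Homo sapiens) for cytotoxicity, read by colorimetric assay (on this read-out higher numbers stand for weaker inhibition and lower numbers for stronger inhibition), compound 1 `O=C(/C=C/c1ccc(CN2C(=O)/C(=C3\Nc4ccccc4\C3=N/O)c3cccc(Cl)c32)cc1)NO` gives 60 nM, compound 2 `O=C(NO)c1ccc(CN2C(=O)/C(=C3\Nc4ccccc4\C3=N/O)c3cccc(Cl)c32)cc1` gives 90 nM and compound 3 `O=C(NO)c1ccc(CN2C(=O)/C(=C3\Nc4ccccc4\C3=N/O)c3cc(Br)ccc32)cc1` gives 70 nM, so compound 1 stands level with the other two, all three values lying within the scatter of one another. Compound 4 `O=C(/C=C/c1ccc(CN2C(=O)/C(=C3\Nc4ccccc4\C3=N/O)c3ccccc32)cc1)NO` has hydrogen in place of chloro on an aromatic carbon of compound 1: hydrogen in place of chloro on an aromatic carbon. For the measured compounds named here, every measured compound carries chloro or bromo, and no measured step removes either. Going by the values given here, the one step available, a 1.5-fold higher number from compound 1 to compound 2 (0.18 log units; within the scatter), exchanges 2-(hydroxycarbamoyl)ethenyl for hydroxycarbamoyl and bears only indirectly. No change beyond the scatter is therefore expected in this assay, and the expected step is a 1.3-fold higher number from compound 1 to compound 4 (0.12 log units; within the scatter). The estimate for compound 4 is 80 nM, with an expected range of 35 nM to 180 nM.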

Compound 4, half-maximal inhibitory concentration: 50 nM
Compound 4: the middle estimate sits 1.6-fold (0.20 log units) above what was measured; low and high end bracket the measured number.
By their numbers in this assay, from the lowest: compounds 4, 1, 3 and 2 (each within the scatter of the next).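

In this assay, for the compounds shown here, this is the first direct reading of the aromatic carbon ortho to a fused ring: a 1.2-fold lower number from compound 1 to compound 4 (0.08 log units; within the scatter). Chloro is thus not needed at this position to keep the number within the scatter, at least with the 2-(hydroxycarbamoyl)ethenyl group in place. Nothing at hand explains this result.

Going by these compounds, whether the same exchange would stay within the scatter with hydroxycarbamoyl in place remains open. So does whether an amine or a carboxylic acid on this carbon would move the number beyond the scatter.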